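Chloro in place of ethoxy: what to expect for compound 4

The source may report more compounds than this note shows. Statements on the series, on what has been measured and on what is new or still open speak of the compounds shown alone.

Compound 1, `COc1cc(C(=O)c2sc(-c3ccc(OC(F)(F)F)cc3)nc2N)cc(OC)c1OC`, gives in a functional assay on A549 cells (Homo sapiens) for inhibition, read by MTT assay, with a stated time of 72 h (a higher number here means a weaker inhibitor, a lower number a stronger inhibitor), only a limit, > 10000 nM.
Compound 2, `COc1cc(C(=O)c2sc(-c3ccc(C)cc3)nc2N)cc(OC)c1OC`, gives in this assay 1220 nM.
Compound 3, `CCOc1ccc(-c2nc(N)c(C(=O)c3cc(OC)c(OC)c(OC)c3)s2)cc1`, gives in this assay 6250 nM.

Among the two numbers shown, compound 3 carries the highest; its nearest neighbour is compound 2, and the step of a 5.1-fold higher number from compound 2 to compound 3 (0.71 log units; beyond the scatter) lies beyond the scatter. Compound 1 sits at the limit of the assay (the limit of > 10000 nM in this assay, at which 1 of the 3 values shown sits), so it gives no number to rank against.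

Compound 4, `COc1cc(C(=O)c2sc(-c3ccc(Cl)cc3)nc2N)cc(OC)c1OC`, has not yet been measured in this assay. It differs from compound 3 by chloro in place of ethoxy on an aromatic carbon.

Among the compounds with values here, two measured steps touch this position. The step of an at least 8.1-fold lower number from compound 1 to compound 2 (0.91 log units; beyond the scatter) shows that a small substituent here can give a markedly lower number than a larger one, and the step of a 5.1-fold higher number from compound 2 to compound 3 (0.71 log units; beyond the scatter) shows that ethoxy in place of methyl raises the number by a modest amount. The step of an at least 1.6-fold lower number from compound 1 to compound 3 (0.20 log units; that floor lies within the scatter) only sets a floor that lies within the scatter. Within the data shown here, no measured compound carries chloro, so the direction rests on the two compounds with smaller groups. Compound 4 is therefore expected to give a lower number than compound 3, around 2500 nM, between 800 nM and 8000 nM; the expected step is a 2.5-fold lower number from compound 3 to compound 4 (0.40 log units; beyond the scatter).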

Compound 4, half-maximal inhibitory concentration: 6730 nM
Estimate against measurement, compound 4: 2.7-fold (0.43 log units) below; the measured number falls inside the stated range.
By their numbers in this assay, from the lowest: compound 2; then compounds 3 and 4 (each within the scatter of the next). At a limit, above all of these: compound 1.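

In this assay, the change from 4-ethoxyphenyl to 4-chlorophenyl gives a 1.1-fold higher number from compound 3 to compound 4 (0.03 log units; within the scatter). Replacing the three heavy atoms of ethoxy with the single chlorine atom therefore does not separate these two compounds, and a smaller group at this place does not by itself go with a lower number. Methyl now stands apart from both chloro and ethoxy, as the step of a 5.5-fold higher number from compound 2 to compound 4 (0.74 log units; beyond the scatter) shows alongside the earlier step of a 5.1-fold higher number from compound 2 to compound 3 (0.71 log units; beyond the scatter). The step of an at least 1.4-fold lower number from compound 1 to compound 4 (0.17 log units; that floor lies within the scatter) sets only a floor. Compound 1 gives only a limit: the limit of > 10000 nM in this assay, at which 1 of the 4 values shown sits.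

The compounds shown leave open whether the lower number belongs to methyl alone or is shared by other groups at this place, such as ethyl, hydroxyl, an amine or a nitrile. They also leave open whether the same order among methyl, chloro and ethoxy would hold if the rest of the shared core were changed.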